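Working notes: from compound 3 to compound 4

The source may report more compounds than this note shows. Statements on the series, on what has been measured and on what is new or still open speak of the compounds shown alone.

Compound 1 `Nc1ccccc1NC(=O)CCCNCC(=O)Nc1cccc([N+](=O)[O-])c1`, compound 2 `Nc1ccccc1NC(=O)CCCNCC(=O)Nc1cc(Cl)ccc1Cl` and compound 3 `Nc1ccccc1NC(=O)CCCNCC(=O)Nc1ccccc1Cl` share one core and differ in the group on an amide-type nitrogen. In a functional assay on HCT-116 cells (Homo sapiens) for inhibition, read by MTT assay, with a stated time of 2 days (a higher number here means that more compound is tolerated, a lower number that less compound is tolerated), compound 1 gives > 100000 nM, which is a limit. Compound 2 gives > 100000 nM, also a limit. Compound 3 gives > 100000 nM, again a limit, so it has no numerical standing in the series. The three values share one ceiling: the limit of > 100000 nM in this assay, at which 3 of the 3 values shown sit.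

Compound 4 `COc1ccc(NC(=O)CNCCCC(=O)Nc2ccccc2N)cc1` brings (4-methoxyphenyl in place of 2-chlorophenyl on an amide-type nitrogen), that is, 4-methoxyphenyl in place of 2-chlorophenyl on an amide-type nitrogen.

Among the compounds with values here, three measured steps bear on this change: a step that the two limits leave unreadable from compound 1 to compound 3, a step that the two limits leave unreadable from compound 1 to compound 2 and a step that the two limits leave unreadable from compound 2 to compound 3. None has a readable size. No step beyond the scatter is therefore expected in this assay, in either direction. This expectation rests on compound 3, whose > 100000 nM is a limit. The expected change is a number no higher from compound 3 to compound 4 (the limit leaves the size open). Compound 4 is estimated at 100000 nM, with an expected range of 30000 nM to 200000 nM.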

Compound 4, concentration lethal to 50% of the cells: > 100000 nM
Compound 4: a limit, no number (the forecaster's own chance of this, stated with the estimate: 80%); the middle value lies on the limit itself.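

In this assay, within the data shown here, compound 4 gives > 100000 nM, which is a limit, so no step linking it to compound 1, compound 2 or compound 3 can be read. The compounds shown leave open whether any group on the amide-type nitrogen changes the read-out, since all share one ceiling: the limit of > 100000 nM in this assay, at which 4 of the 4 values shown sit.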